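Series note: ethyl in place of trifluoromethyl

A few compounds are considered here, and "the series" means these few. Any claim that something is new, unique, unknown or untested is made for them only; others in the source may bear on it.

In a physicochemical assay for solubility, measured as kinetic solubility (on this read-out higher numbers stand for higher solubility and lower numbers for lower solubility), compound 1 `Cc1cc2c(Oc3cnc(C(=O)N(C)C)cn3)cc(C(=O)Nc3cnccn3)cc2o1` gives 30000 nM and compound 2 `Cc1cc2c(Oc3cnc(C(=O)N(C)C)cn3)cc(C(=O)Nc3cnc(C(F)(F)F)cn3)cc2o1` gives 6000 nM, so compound 2 holds the lower of the two numbers. Compound 3 `CCc1cnc(NC(=O)c2cc(Oc3cnc(C(=O)N(C)C)cn3)c3cc(C)oc3c2)cn1` follows from compound 2 by one change: ethyl in place of trifluoromethyl on an aromatic carbon.

Going by the values given here, only one measured step bears on this: a 5.0-fold lower number from compound 1 to compound 2 (0.70 log units; beyond the scatter), a modest step beyond the scatter, made by trifluoromethyl entering in place of hydrogen. Among the compounds with values here, no measured compound carries ethyl, so this guide is indirect. It sets the scale and suggests a partial return towards the higher number. The expected step is small and upward: a 1.7-fold higher number from compound 2 to compound 3 (0.22 log units; within the scatter). In this assay, compound 3 is expected at 10000 nM, with an estimated range from 3500 nM to 30000 nM.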

Compound 3, solubility: 117000 nM
Compound 3: the middle estimate sits 12-fold (1.07 log units) below what was measured; measured number above the stated range.
By their numbers in this assay, from the lowest: compound 2; then compound 1; then compound 3.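

In this assay, the change from 5-(trifluoromethyl)pyrazin-2-yl to 5-ethylpyrazin-2-yl gives a 20-fold higher number from compound 2 to compound 3 (1.29 log units; beyond the scatter), which shows that this position can carry a large step and not only the modest one seen earlier. Ethyl does more than cancel the earlier loss: relative to hydrogen on the same aromatic carbon, it gives a 3.9-fold higher number from compound 1 to compound 3 (0.59 log units; beyond the scatter), so the number at this position can move in either direction from hydrogen. No data at hand account for the opposite directions of these two groups.

Still open, as far as these compounds go, is whether the rise is particular to ethyl or extends to methyl, or to a longer chain such as propyl. From the compounds shown here alone, a primary amine or a carboxylic acid at this carbon would test the position with a different kind of group, and how far the same order of hydrogen, trifluoromethyl and ethyl carries to other cores also remains unknown.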